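A Cyclopropane Acid Replaces the Propanoic Acid Chain

The compounds below may be only part of what the source reports. "The series", "measured", "known", "first", "only" and "open" are said of these compounds alone.

Compound 1 `Cc1cc(CCC(=O)O)ccc1-c1noc(-c2ccc(OC(C)C)c(C#N)c2)n1` was examined in an assay on CHO cells for displacement of a labelled ligand from sphingosine 1-phosphate receptor 2 (Homo sapiens); on this read-out lower numbers stand for stronger inhibition and higher numbers for weaker inhibition. In this assay compound 1 gives > 10000 nM, which is a limit of the assay rather than a number. Compound 2 `Cc1cc([C@@H]2C[C@H]2C(=O)O)ccc1-c1noc(-c2ccc(OC(C)C)c(C(F)(F)F)c2)n1` in this assay gives > 10000 nM, again only a limit. Both values sit at the limit of > 10000 nM in this assay, at which 2 of the 2 values shown sit, so compound 1 can be placed only alongside compound 2, with neither showing measurable binding here.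

Compound 3 `Cc1cc([C@H]2C[C@H]2C(=O)O)ccc1-c1noc(-c2ccc(OC(C)C)c(C#N)c2)n1` has not yet been measured in this assay. It differs from compound 1 by 2-carboxycyclopropyl in place of 2-carboxyethyl on an aromatic carbon. Going by the values given here, no measured pair isolates this change; compound 2, which also carries a 2-carboxycyclopropyl group but a trifluoromethyl group instead of the nitrile, shows only a limit. Compound 3 is expected to stay at or near the limit, with a step that the limit leaves unreadable from compound 1 to compound 3 expected to remain within the scatter. The estimate for compound 3 is 15000 nM, within a range from 4000 nM to 60000 nM.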

Compound 3, half-maximal inhibitory concentration: > 10000 nM
Compound 3: only a limit was reported; the forecaster's own chance of this, stated with the estimate: 75%; the middle value does not contradict the limit.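

The result for compound 3 is again only a limit, and compound 1 also has only a limit, so no step can be read between compound 1 and compound 3: the limit of > 10000 nM in this assay, at which 3 of the 3 values shown sit.

The compounds shown leave open whether 2-carboxycyclopropyl in place of 2-carboxyethyl changes the result in this assay at all, since none of them gives a number there.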